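The compounds below may be only part of what the source reports. "The series", "measured", "known", "first", "only" and "open" are said of these compounds alone.

Compound 1, whose structure is `N#CC1CN1C(=O)Nc1ccc([N+](=O)[O-])cc1`, carries a nitro group on the aromatic ring of its core. In a functional assay on L1210 cells (Mus musculus) for inhibition, read by MTT assay (a higher number here means a weaker inhibitor, a lower number a stronger inhibitor), compound 1 gives 2600 nM. For the measured compounds named here, the only other measured compound, compound 2, with the structure `N#CC1CN1C(=O)Nc1cccc2ccccc12`, gives 2500 nM in this assay; compound 1 has the higher of the two numbers, but the two values lie within the scatter of each other, so nothing separates them. Going by the values given here, no step between measured compounds is available to guide the next change. Compound 3, with the structure `N#CC1CN1C(=O)Nc1ccc(S(N)(=O)=O)cc1`, differs from compound 1 by sulfamoyl in place of nitro on an aromatic carbon, a sulfamoyl in place of nitro on an aromatic carbon. Among the compounds with values here, with no measured step of this kind to rest on, the expected step from compound 1 to compound 3 in this assay is a 1.5-fold higher number from compound 1 to compound 3 (0.19 log units; within the scatter), a modest rise in the half-maximal inhibitory concentration, toward weaker inhibition, that may not exceed the scatter. Compound 3 is therefore estimated at 4000 nM, within a range of 1500 nM to 12000 nM.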

Compound 3, half-maximal inhibitory concentration: > 38000 nM
Compound 3: only a limit was reported; the forecaster's own chance of this, stated with the estimate: 5%; middle value at least 9.5-fold (0.97 log units) from the limit.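

Swapping nitro for sulfamoyl on this aromatic carbon gives an at least 14-fold higher number from compound 1 to compound 3 (1.16 log units; beyond the scatter) in this assay, a large move toward weaker inhibition. Before this result there was no measured step at all, so this is the first sign that the group at this place can strongly affect inhibition in this series. Compound 3 has only a limit of the assay rather than a number, so the full size of the step is not known: the limit of > 38000 nM in this assay, at which 1 of the 3 values shown sits.

This single swap does not show which feature of sulfamoyl lies behind the step. On these data alone, it also remains open whether an amine or a carboxylic acid on the same aromatic carbon would stay close to compound 1 or lose inhibition as compound 3 does.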